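Amide nitrogen substituents on a shared core, paw-edema read-out

The source may hold more compounds than are shown below. What is called first, only, known or untested is meant among the compounds shown, and "the series" means these compounds.

Measured compounds:
compound 1 `COc1cc2c(cc1OC)C(CC(N)=O)CC2` — 31%
compound 2 `COc1cc2c(cc1OC)C(CC(=O)NC(C)C)CC2` — 37%
compound 3 `CCCCCNC(=O)CC1CCc2cc(OC)c(OC)cc21` — 34%

In a functional assay on the whole organism (strain Wistar) for inhibition, with Rattus norvegicus as the target, read by paw edema, with stated times of 60 min and 2 h, at a dose of 100 mg/kg by the oral route (on this read-out lower numbers stand for less inhibition and higher numbers for more inhibition at the one dose given (going by the name of the read-out)), the three measured compounds lie close together. Compound 3 sits within the scatter of both others: a number 3 percentage points higher from compound 1 to compound 3 (within the scatter) and a number 3 percentage points lower from compound 2 to compound 3 (within the scatter), and likewise a number 6 percentage points higher from compound 1 to compound 2 (within the scatter). Replacing the amide hydrogen of compound 1 by isopropyl or pentyl, or swapping one of these for the other, has so far given no step beyond the scatter in this assay.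

Compound 4 `COc1cc2c(cc1OC)C(CC(=O)NCc1ccccc1)CC2` differs from compound 3 by phenyl in place of butyl on a saturated chain carbon bound to an amide-type nitrogen. Among the compounds with values here, the steps that bear on this are the earlier changes at the amide nitrogen, a number 3 percentage points higher from compound 1 to compound 3 (within the scatter) and a number 3 percentage points lower from compound 2 to compound 3 (within the scatter), both within the scatter. Within the data shown here, no measured step tells how an aromatic ring on the amide substituent behaves here, so nothing beyond the scatter is expected: the estimated a number 1 percentage points higher from compound 3 to compound 4 (within the scatter). Compound 4 is therefore estimated at 35%, with a range from 22% to 48%.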

Compound 4, a percentage reported as inhibition, in the whole organism at one dose (the size of the read-out at that dose, not a potency): 24%
Estimate against measurement, compound 4: 11 percentage points above; measured number inside the range.
By their numbers in this assay, from the lowest: compounds 4, 1, 3 and 2 (each within the scatter of the next, the first and the last beyond it).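

Within the data shown here, at the amide nitrogen, benzyl gives the first step beyond the scatter in this assay (a number 13 percentage points lower from compound 2 to compound 4 (beyond the scatter)), a modest step measured against isopropyl. Compound 4 remains within the scatter of the other two compounds (a number 10 percentage points lower from compound 3 to compound 4 (within the scatter); a number 7 percentage points lower from compound 1 to compound 4 (within the scatter)), so phenyl in place of butyl on a saturated chain carbon bound to an amide-type nitrogen does not separate it from the pentyl amide, and benzyl does not separate it from the unsubstituted amide. Among these compounds, nothing available accounts for the single step beyond the scatter.

Still open, from the compounds shown here alone, is whether that step belongs to the aromatic ring or to its distance from the amide nitrogen, which a phenyl directly on that nitrogen or a 2-phenylethyl group would address. Also open, going by these compounds, is how a benzyl ring carrying a carboxylic acid or an amine would read out at this one dose.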